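The source may hold more compounds than are shown below. What is called first, only, known or untested is meant among the compounds shown, and "the series" means these compounds.

Compound 1, `Cc1ncn2c(O)nncc12`, is the point of departure. In a functional assay for inhibition, with Homo sapiens as the target (a higher number here means a weaker inhibitor, a lower number a stronger inhibitor), compound 1 gives > 48000 nM, which is a limit of the assay rather than a number. Compound 2, `CCc1nc(C)c2cnnc(O)n12`, carries an ethyl in place of hydrogen on an aromatic carbon; in this assay compound 2 gives > 48000 nM, again a limit. Compound 3, `Cc1nc(C)n2c(O)nncc12`, carries a methyl in place of hydrogen on an aromatic carbon; in this assay compound 3 gives > 48000 nM, also a limit. The measured steps are therefore a step that the two limits leave unreadable from compound 1 to compound 2, a step that the two limits leave unreadable from compound 1 to compound 3 and a step that the two limits leave unreadable from compound 2 to compound 3, which follows from the limit of > 48000 nM in this assay, at which 3 of the 3 values shown sit.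

Compound 4, `Cc1ncn2c(NN)nncc12`, differs from compound 1 by aminoamino in place of hydroxy on an aromatic carbon. None of the three measured steps changes this part of the shared core, and none of them has a readable size, so no direction or magnitude can be drawn from them; the most probable outcome is a further limit. The step expected in this assay is an at least 1.2-fold lower number from compound 1 to compound 4 (0.07 log units; that floor lies within the scatter). Compound 4 is estimated at 40000 nM, with a range from 5000 nM to 150000 nM.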

Compound 4, half-maximal inhibitory concentration: > 48000 nM
Compound 4: no number, only a limit; the forecaster's own chance of this, stated with the estimate: 70%; middle value at least 1.2-fold (0.07 log units) away from the limit.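

In this assay, compound 1 and compound 4 each give only a limit, so the step between them cannot be read, and the same holds for every compound shown: the limit of > 48000 nM in this assay, at which 4 of the 4 values shown sit. The compounds shown leave open which change to the shared core, if any, would give a readable number.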